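This account rests on a few compounds, and the source may have more. Where it says the series, first, only, none or still open, it means among the compounds named here.

In a functional assay on KYSE-70 cells for antiproliferative activity against KYSE-70 cell line (Homo sapiens), read by MTT assay, with a stated time of 72 h (on this read-out lower numbers stand for stronger inhibition and higher numbers for weaker inhibition), compound 1 (`O=C(Nc1cccc(F)c1)c1cc(=O)[nH]c2cc(-c3ccc(F)cc3)ccc12`) gives 3300 nM. Compound 2 (`COc1ccc(-c2ccc3c(C(=O)Nc4cccc(F)c4)cc(=O)[nH]c3c2)cc1`) gives > 20000 nM, which is a limit. Compound 3 (`Nc1ccc(-c2ccc3c(C(=O)Nc4cccc(F)c4)cc(=O)[nH]c3c2)cc1`) gives > 20000 nM, also a limit, so it has no exact number. This is the limit of > 20000 nM in this assay, at which 2 of the 3 values shown sit. Compound 4 (`O=C(Nc1cccc(F)c1)c1cc(=O)[nH]c2cc(-c3ccc(F)c(CO)c3)ccc12`) carries 4-fluoro-3-(hydroxymethyl)phenyl in place of 4-aminophenyl on an aromatic carbon. Going by the values given here, two measured steps bear on this, an at least 6.0-fold higher number from compound 1 to compound 2 (0.78 log units; beyond the scatter) and an at least 6.0-fold higher number from compound 1 to compound 3 (0.78 log units; beyond the scatter), and both moved away from the fluoro group that compound 4 keeps. Among the compounds with values here, no measured compound carries the hydroxymethyl group, so the size remains uncertain. A lower number is expected, an estimated at least 3.3-fold lower number from compound 3 to compound 4 (0.52 log units; beyond the scatter). Compound 4 is expected near 6000 nM, with an estimated range from 1500 nM to 20000 nM.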

Compound 4, half-maximal inhibitory concentration: > 20000 nM
Compound 4 ended at the assay's limit; the forecaster's own chance of this, stated with the estimate: 30%; at least 3.3-fold (0.52 log units) between middle value and limit.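

Hydroxymethyl in place of hydrogen on the outer ring of compound 1 gives an at least 6.0-fold higher number from compound 1 to compound 4 (0.78 log units; beyond the scatter) in this assay. Until now, only replacing the fluoro group had raised the number, but here the fluoro group stays and one added group is enough. Compound 4 gives a limit rather than an exact number: the limit of > 20000 nM in this assay, at which 3 of the 4 values shown sit.

The steps among compounds 2, 3 and 4 therefore cannot be read. On these data alone, whether a methyl or a chlorine at the hydroxymethyl position would keep the activity of compound 1 remains open.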